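The compounds below may be only part of what the source reports. "The series", "measured", "known", "first", "only" and "open" are said of these compounds alone.

In a functional assay, read by fluorescence and spectrophotometry, with a stated time of 1 h; on this read-out lower numbers stand for an effect already at smaller amounts and higher numbers for an effect only at larger amounts of compound:
- compound 1 `C=CCCCCCCCS(=O)(=O)/C=C/c1ccc(O)c(O)c1`: 6900 nM
- compound 2 `O=S(=O)(/C=C/c1ccc(O)c(O)c1)CC1CCCN1`: 13800 nM
- compound 3 `O=S(=O)(/C=C/c1ccc(O)c(O)c1)CC1CCCO1`: 10500 nM

Compound 3 lies within the scatter of both compound 1 and compound 2, so the numbers give it no separate standing.

Compound 4 `CCCCCCCS(=O)(=O)/C=C/c1ccc(O)c(O)c1` carries hexyl in place of oxolan-2-yl on a saturated chain carbon bound to a sulfonyl sulfur.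

Among the compounds with values here, only one measured step changes a single place, and it concerns the same group: a 1.3-fold lower number from compound 2 to compound 3 (0.12 log units; within the scatter). That step replaces a ring with another ring, so it says little about replacing a ring with an open chain. The closest measured comparison is compound 1 at 6900 nM, which also has an open chain, though not the same one. Neither observation points to a large shift in this assay.

The expected step is a 1.2-fold lower number from compound 3 to compound 4 (0.09 log units; within the scatter), so no change beyond the scatter is anticipated. The estimate for compound 4 is 8500 nM, with an expected range of 4000 nM to 17000 nM.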

Compound 4, half-maximal effective concentration: 7100 nM
The estimate for compound 4 lay 1.2-fold (0.08 log units) above the measured number; the range from low to high includes it.
By their numbers in this assay, from the lowest: compounds 1, 4, 3 and 2 (each within the scatter of the next).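

In this assay, the open hexyl chain on a saturated chain carbon bound to a sulfonyl sulfur cannot be told apart from either ring-bearing compound (a 1.5-fold lower number from compound 3 to compound 4 (0.17 log units; within the scatter); a 1.9-fold lower number from compound 2 to compound 4 (0.29 log units; within the scatter)), so among these compounds neither a ring nor a ring hetero atom at this place is required for a number in this range. The terminal vinyl also makes no readable difference (a 1.0-fold higher number from compound 1 to compound 4 (0.01 log units; within the scatter)), which means the open chain tolerates both a saturated and an unsaturated end here. No measurement at hand explains this flat picture.

As far as these compounds go, it remains open whether a terminal carboxylic acid on the chain, or a phenyl ring at this place, would give a step beyond the scatter. From the compounds shown here alone, a much shorter chain such as ethyl, or a chain longer than hexyl, is equally open.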